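Furanylmethyl Amide Weighed Against the Anilide

The compounds below may be only part of what the source reports. "The series", "measured", "known", "first", "only" and "open" are said of these compounds alone.

Compound 2 `O=C(Cn1c(=O)oc2cc(Cl)ccc21)Nc1ccccc1` stands lowest among the three compounds measured in an ADME assay on RAW264.7 cells (Mus musculus) for cytotoxicity, read by MTT assay, with a stated time of 72 h, tested at 100 uM (on this read-out higher numbers stand for a stronger effect at the one concentration tested and lower numbers for a weaker effect), where compound 2 gives 20.2%. Its nearest neighbour is compound 3 `O=C(Cn1c(=O)oc2ccccc21)Nc1ccccc1`, which in this assay gives 39.8%; the step of a number 19.6 percentage points higher from compound 2 to compound 3 (beyond the scatter) came with hydrogen in place of chloro on an aromatic carbon. Furthest away is compound 1 `O=C(Cn1c(=O)oc2cc(Cl)ccc21)NCc1cccs1`, which gives 53.6% in this assay; the step of a number 33.4 percentage points lower from compound 1 to compound 2 (beyond the scatter) came with phenyl in place of (thiophen-2-yl)methyl on an amide-type nitrogen.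

Compound 4 `O=C(Cn1c(=O)oc2cc(Cl)ccc21)NCc1ccco1` differs from compound 2 as follows: (furan-2-yl)methyl in place of phenyl on an amide-type nitrogen. The step that bears most directly on this change is a number 33.4 percentage points lower from compound 1 to compound 2 (beyond the scatter): compound 1 carries (thiophen-2-yl)methyl on the same amide-type nitrogen and keeps the chloro, and compound 4 carries (furan-2-yl)methyl there. The step of a number 19.6 percentage points higher from compound 2 to compound 3 (beyond the scatter) touches a different place and only shows how the shared core responds elsewhere. Running the first step backwards, a rise beyond the scatter is expected, roughly recovering what was lost between compound 1 and compound 2.

For compound 4 the expected value in this assay is 48%, with a range from 30% to 65%. This expectation amounts to a step of a number 27.8 percentage points higher from compound 2 to compound 4 (beyond the scatter).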

Compound 4, a percentage reported as inhibition, at one concentration (the size of the read-out at that concentration, not a potency): 50.3%
The estimate for compound 4 lay 2.3 percentage points below the measured number, within the range that was stated.
By their numbers in this assay, from the lowest: compound 2; then compound 3; then compounds 4 and 1 (each within the scatter of the next).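

With the chloro kept, this assay shows a second group on the amide-type nitrogen that stands well clear of the anilide: the change to (furan-2-yl)methyl gives a number 30.1 percentage points higher from compound 2 to compound 4 (beyond the scatter) and so runs the same way as the comparison of compound 2 with compound 1, which until now rested on one group alone. The new pair also shows that the ring on the saturated chain carbon can be exchanged with no readable effect, since furan-2-yl in place of thiophen-2-yl gives a number 3.3 percentage points lower from compound 1 to compound 4 (within the scatter) and leaves the two compounds together, with compound 2 apart from both. Nothing at hand gives a reason for the size of the step from the phenyl compound.

The compounds shown leave open whether the higher number goes with the saturated chain carbon or with the five-membered ring, a question that a benzyl group on the same nitrogen would separate, and whether a longer chain such as 2-(furan-2-yl)ethyl would keep it. As far as these compounds go, it also stays open whether hydrogen in place of chloro acts on the (furan-2-yl)methyl amide as it does on the anilide.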